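The compounds below may be only part of what the source reports. "The series", "measured", "known", "first", "only" and "open" are said of these compounds alone.

Compound 1 `O=C(Nc1cccc(-n2cc(-c3ccncc3)c(-c3ccc(Cl)c(O)c3)n2)c1)Nc1ccc(Cl)c(Cl)c1` gives 6970 nM in a functional assay on M14 cells (Homo sapiens) for inhibition, read by sulforhodamine B assay, with a stated time of 48 h; a lower number here means a stronger inhibitor of growth, a higher number a weaker inhibitor of growth. Compound 3 `COc1cc(-c2nn(-c3cccc(NC(=O)Nc4ccc(Cl)c(C(F)(F)F)c4)c3)cc2-c2ccncc2)ccc1Cl` gives 3710 nM in this assay, a gap to compound 1 that sits within the scatter, so the two stand together on the numbers shown. For compound 2 `COc1cc(-c2nn(-c3cccc(NC(=O)c4ccc(Cl)c(C(F)(F)F)c4)c3)cc2-c2ccncc2)ccc1Cl` the assay returns only a limit, > 32500 nM (the limit of > 32500 nM in this assay, at which 1 of the 3 values shown sits). Among the compounds with values here, the single measured step, an at least 8.7-fold lower number from compound 2 to compound 3 (0.94 log units; beyond the scatter), concerns the carbonyl carbon and not the amide-type nitrogen. Compound 4 `O=C(Nc1cccc(-n2cc(-c3ccncc3)c(-c3ccc(Cl)c(O)c3)n2)c1)Nc1cccc(C(F)(F)F)c1` differs from compound 1 by 3-(trifluoromethyl)phenyl in place of 3,4-dichlorophenyl on an amide-type nitrogen. Within the data shown here, no measured step touches that place, so no shift beyond the scatter is expected, a 1.0-fold higher number from compound 1 to compound 4 (0.00 log units; within the scatter). Compound 4 is therefore estimated at 7000 nM, with a range of 2500 nM to 20000 nM.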

Compound 4, concentration for total growth inhibition: 10800 nM
The estimate for compound 4 lay 1.5-fold (0.19 log units) below the measured number; low and high end bracket the measured number.
By their numbers in this assay, from the lowest: compounds 3, 1 and 4 (each within the scatter of the next, the first and the last beyond it). At a limit, above all of these: compound 2.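

Within the data shown here, this is the first measured step at the amide-type nitrogen: in this assay, a 1.5-fold higher number from compound 1 to compound 4 (0.19 log units; within the scatter), with 3-(trifluoromethyl)phenyl in place of 3,4-dichlorophenyl. On the core of compound 1, these two aryl groups are therefore not separated by the numbers shown. No measurement shown bears on why this exchange leaves the number within the scatter. From the compounds shown here alone, it remains open whether this place also accepts a group without the aromatic ring, such as cyclohexyl or a longer alkyl chain. Going by these compounds, a phenyl ring carrying an amine or a carboxylic acid is equally open.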